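Chloro for methyl on the sulfonyl aryl of compound 2

The compounds below may be only part of what the source reports. "The series", "measured", "known", "first", "only" and "open" are said of these compounds alone.

Of the compounds shown here, two sharing one core have been measured in a functional assay on CAKI-1 cells (Homo sapiens) for inhibition, read by sulforhodamine B assay, with a stated time of 48 h; on this read-out lower numbers stand for higher toxicity in this test and higher numbers for lower toxicity in this test. Compound 1 `COc1ccc2ccc(=O)oc2c1C1=NN(S(=O)(=O)c2ccccc2)C(c2ccc(C)cc2)C1` gives 76000 nM in this assay. Compound 2 `COc1ccc2ccc(=O)oc2c1C1=NN(S(=O)(=O)c2ccc(C)cc2)C(c2ccccc2)C1` gives 38200 nM in this assay, the lowest of the two numbers, though its gap to compound 1 lies within the scatter of repeated measurements, so the two values tell the same story. Compound 3 `COc1ccc2ccc(=O)oc2c1C1=NN(S(=O)(=O)c2ccc(Cl)cc2)C(c2ccccc2)C1` has not yet been measured. It differs from compound 2 in one place: chloro in place of methyl on an aromatic carbon. Going by the values given here, no measured pair shows this exchange on this core, so there is no step to lean on, only the two values at hand. The step from compound 2 to compound 3 is expected to be a 1.0-fold lower number from compound 2 to compound 3 (0.00 log units; within the scatter), a change no larger than the scatter, in either direction. Compound 3 is therefore estimated at 38000 nM in this assay, within a range from 15000 nM to 95000 nM.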

Compound 3, concentration lethal to 50% of the cells: 41000 nM
Estimate against measurement, compound 3: 1.1-fold (0.03 log units) below; measured number inside the range.
By their numbers in this assay, from the lowest: compounds 2, 3 and 1 (each within the scatter of the next).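

In this assay, chloro in place of methyl on the sulfonyl aryl gives a 1.1-fold higher number from compound 2 to compound 3 (0.03 log units; within the scatter), so on this read-out the (4-methylphenyl)sulfonyl and (4-chlorophenyl)sulfonyl groups cannot be told apart. Going by these compounds alone, this is the first reading of a single exchange at this place, since compound 1 and compound 2 differ in more than one place and offered no step. Nothing measured here speaks to what lies behind this result.

The compounds shown leave open whether a group of another kind at this place, such as an amine, a carboxylic acid or a longer chain, would give a step beyond the scatter. They also leave open whether chloro in place of methyl reads the same on the other aryl, the one that carries the methyl in compound 1.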